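The compounds below may be only part of what the source reports. "The series", "measured", "known", "first", "only" and "open" are said of these compounds alone.

Compound 1 `BrCCCCOc1nc(/C=C/c2ccccc2)cc(/C=C/c2ccccc2)n1` gives > 20000 nM in a functional assay on HT-29 cells (Homo sapiens) for cytotoxicity, read by fluorescence and resazurin assay, with a stated time of 48 h (on this read-out lower numbers stand for stronger inhibition and higher numbers for weaker inhibition), which is a limit of the assay.
Compound 2 `BrCCCCCCOc1nc(/C=C/c2ccccc2)cc(/C=C/c2ccccc2)n1` gives > 20000 nM in this assay, again a limit.

The step that the two limits leave unreadable from compound 1 to compound 2 cannot be read, because of the limit of > 20000 nM in this assay, at which 2 of the 2 values shown sit. Compound 2 thus stands only at the limit on the numbers shown. Compound 3 `BrCCCCCOc1nc(/C=C/c2ccccc2)cc(/C=C/c2ccccc2)n1` differs from compound 2 by bromo in place of bromomethyl on a saturated chain carbon, five bonds along the chain from an oxygen on an aromatic ring. Going by the values given here, the single measured step that bears on this change, from compound 1 to compound 2, is unreadable, so no step beyond the scatter in either direction is expected in this assay. Compound 3 is expected to give 30000 nM, in the range 10000 nM to 100000 nM. The estimated step that the limit leaves unreadable from compound 2 to compound 3 is expected to stay within the scatter.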

Compound 3, half-maximal inhibitory concentration: > 20000 nM
Compound 3 was reported as a limit; the forecaster's own chance of this, stated with the estimate: 85%; the middle value does not contradict the limit.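

Going by these compounds alone, no step among compound 1, compound 2 and compound 3 can be read in this assay, because all three values are limits: the limit of > 20000 nM in this assay, at which 3 of the 3 values shown sit.

The compounds shown leave open whether the length of the chain carrying the bromo group has any effect on cytotoxicity.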